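This account rests on a few compounds, and the source may have more. Where it says the series, first, only, none or still open, it means among the compounds named here.

The measured compounds:
Compound 1 `COc1ccc(-c2cccc(C(=O)N(C)C)c2)cc1S(=O)(=O)Nc1ccc2ccc(N(C)C(=O)c3ccccc3)cc2c1` in a functional assay on CHO cells for agonist activity at Orexin receptor type 2 (Homo sapiens) (on this read-out higher numbers stand for an effect only at larger amounts of compound and lower numbers for an effect already at smaller amounts), gives > 10000 nM, which is a limit of the assay.
Compound 2 `COc1cccc(C(=O)Nc2cccc3ccc(NS(=O)(=O)c4cc(-c5cccc(C(=O)N(C)C)c5)ccc4OC)cc23)c1` in this assay gives 24.3 nM.
Compound 3 `COc1ccccc1C(=O)N(C)c1cccc2ccc(NS(=O)(=O)c3cc(-c4cccc(C(=O)N(C)C)c4)ccc3OC)cc12` in this assay gives > 10000 nM, also a limit of the assay.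

Compound 2 is the only one of the three with a number rather than a limit, and so it stands as the sole point of reference. Compound 4 `COc1ccc(C(=O)N(C)c2cccc3ccc(NS(=O)(=O)c4cc(-c5cccc(C(=O)N(C)C)c5)ccc4OC)cc23)cc1` is not yet measured; it differs from compound 2 by ((4-methoxyphenyl)carbonyl)(methyl)amino in place of ((3-methoxyphenyl)carbonyl)amino on an aromatic carbon.

For the measured compounds named here, one measured step bears on this change. The step of an at least 410-fold higher number from compound 2 to compound 3 (2.61 log units; beyond the scatter) shows that placing a methyl on the amide nitrogen and moving the methoxy group wipes out the measurable effect. Compound 1, which also carries a methyl on the amide nitrogen, sits at the same limit, as described by the limit of > 10000 nM in this assay, at which 2 of the 3 values shown sit. Compound 4 shares the methyl on the amide nitrogen with compound 3 and compound 1, and differs from compound 3 only in the place of the methoxy group.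

Compound 4 is therefore expected to lose most or all of the effect seen for compound 2, with the step of a 330-fold higher number from compound 2 to compound 4 (2.52 log units; beyond the scatter) expected to be large. The estimate for compound 4 is 8000 nM, ranging from 800 nM to 40000 nM, with a substantial chance that only a limit is reported.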

Compound 4, half-maximal effective concentration: 51.1 nM
Beside the measured number, compound 4's estimate is 160-fold (2.19 log units) above it; the whole stated range lies above it.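

The methyl on the amide nitrogen does not by itself remove the effect in this assay, since the change to ((4-methoxyphenyl)carbonyl)(methyl)amino gives a 2.1-fold higher number from compound 2 to compound 4 (0.32 log units; beyond the scatter). With that methyl in place, the position of the methoxy group now separates a measurable effect from none, as 4-methoxyphenyl in place of 2-methoxyphenyl on a carbonyl carbon gives an at least 190-fold lower number from compound 3 to compound 4 (2.29 log units; beyond the scatter). Compound 3 sits at a limit of the assay, so this step gives a bound and not an exact size: the limit of > 10000 nM in this assay, at which 2 of the 4 values shown sit.

The compounds shown do not separate the contribution of the methyl from that of the shift of the methoxy group, as compound 2 and compound 4 differ in both, and a pair with 3-methoxyphenyl and the methyl, or with 4-methoxyphenyl and the amide hydrogen, would be needed to tell them apart. As far as these compounds go, it also remains open how this position would respond to an ethyl group in place of the methyl on the amide nitrogen, or to a dimethylamino group or a carboxylic acid in place of the methoxy group.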